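Bromo in Place of Chloro: What to Expect for Compound 4

The compounds below may be only part of what the source reports. "The series", "measured", "known", "first", "only" and "open" are said of these compounds alone.

Three compounds have been measured in an assay on isolated protein for inhibition of acid-sensing ion channel 3 (Homo sapiens), read by patch clamp, tested at 1 uM; on this read-out lower numbers stand for less inhibition and higher numbers for more inhibition at the one concentration tested (going by the name of the read-out):

compound 1, `N=C(N)c1ccc2[nH]c(-c3cc(F)cc(Cl)c3)cc2c1`, gives 82%
compound 2, `N=C(N)c1ccc2cc(-c3ccccc3)[nH]c2c1`, gives 18%
compound 3, `Cc1cc(Cl)cc(-c2cc3cc(C(=N)N)ccc3[nH]2)c1`, gives 87%

Compound 1 stands second highest of the three numbers. Its nearest neighbour is compound 3, reached by a step of a number 5 percentage points higher from compound 1 to compound 3 (within the scatter), which stays within the scatter of repeated measurements. Its furthest is compound 2, which carries a bare phenyl group and gives a number far lower than compound 1, a gap beyond the scatter.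

The unmeasured compound 4 is `N=C(N)c1ccc2[nH]c(-c3cc(F)cc(Br)c3)cc2c1`. Compared with compound 1 it differs in one place: bromo in place of chloro on an aromatic carbon. Going by the values given here, only one measured step bears on this kind of swap, the exchange of one small group for another on the same ring, namely the step from compound 1 to compound 3 of a number 5 percentage points higher from compound 1 to compound 3 (within the scatter), which made no difference beyond the scatter. Compound 2 shows that taking both groups off the ring matters, but compound 4 keeps both. Bromo in place of chloro is therefore expected to give a step of no change at the digits printed from compound 1 to compound 4 (within the scatter) in this assay, none beyond the scatter. The estimate for compound 4 is 82%, with a range from 66% to 93%.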

Compound 4, a percentage reported as inhibition, at one concentration (the size of the read-out at that concentration, not a potency): 93%
For compound 4 the middle estimate is 11 percentage points below the measured one, within the range that was stated.
By their numbers in this assay, from the lowest: compound 2; then compounds 1, 3 and 4 (each within the scatter of the next, the first and the last beyond it).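

In this assay, putting bromo in place of chloro on this aromatic carbon, meta to a fluoro group, gives a number 11 percentage points higher from compound 1 to compound 4 (beyond the scatter), so a modest change can be read at this position even though one halogen atom simply replaces another and the counts of heavy atoms, hydrogen-bond donors and acceptors stay the same. Going by these compounds alone, the only earlier swap between compounds that differ in one place, at the fluoro group on the same ring, gives a number 5 percentage points higher from compound 1 to compound 3 (within the scatter) and so could not show a change of this kind; the new step is the first single-group swap on this ring to lie beyond the scatter. The data offer no measurement that would explain the step.

Going by these compounds, whether the trend continues with iodo at this position, or what a trifluoromethyl group, a methoxy group or an amine would do there, stays open, as does whether bromo gives a similar step when methyl takes the place of fluoro on the ring. On these data alone, each number also comes from a single tested concentration, so how the compounds compare in potency remains unknown.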